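This account rests on a few compounds, and the source may have more. Where it says the series, first, only, none or still open, it means among the compounds named here.

Measured so far:
- compound 1, `COc1cccc(OC)c1OCCNCCOc1ccccc1OCc1ccccc1C`: 7.67
- compound 2, `COc1ccccc1COc1ccccc1OCCNCCOc1c(OC)cccc1OC`: 8.13
- compound 3, `COc1ccc(COc2ccccc2OCCNCCOc2c(OC)cccc2OC)cc1`: 9.51

In a functional assay on spleen for antagonist activity at Alpha-1B adrenergic receptor (Rattus norvegicus) (a lower number here means a less potent compound, a higher number a more potent compound, by a factor of ten per unit of this negative logarithm), compound 3 stands highest of the three, with compound 2 nearest and compound 1 furthest, both beyond the scatter. Compound 4, `CCOc1ccc(COc2ccccc2OCCNCCOc2c(OC)cccc2OC)cc1`, differs from compound 3 by methyl in place of hydrogen on a saturated chain carbon bound to an oxygen on an aromatic ring. For the measured compounds named here, no measured step alters this group in the same way; the steps of a number 1.84 log units higher from compound 1 to compound 3 (beyond the scatter) and a number 1.38 log units higher from compound 2 to compound 3 (beyond the scatter) show that the group on this chain carbon matters greatly, while a number 0.46 log units higher from compound 1 to compound 2 (beyond the scatter) is modest. Going by the values given here, with no step exchanging hydrogen for methyl here, compound 4 is expected to stay close to compound 3 in this assay, the estimated step being a number 0.21 log units lower from compound 3 to compound 4 (within the scatter). Compound 4 is thus estimated at 9.3, between 8.6 and 9.9.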

Compound 4, negative logarithm of the antagonist equilibrium constant: 8.23
Beside the measured number, compound 4's estimate is 1.07 log units above it; measured number outside the range, below it.
By their numbers in this assay, from the lowest: compound 1; then compounds 2 and 4 (each within the scatter of the next); then compound 3.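

In this assay this position answers to a single added methyl, not only to exchange of the whole group on the chain carbon: going from 4-methoxyphenyl to 4-ethoxyphenyl gives a number 1.28 log units lower from compound 3 to compound 4 (beyond the scatter) in this series. Little of the earlier gain survives, with a number 0.56 log units higher from compound 1 to compound 4 (beyond the scatter) still seen while a number 0.10 log units higher from compound 2 to compound 4 (within the scatter) leaves 4-ethoxyphenyl level with 2-methoxyphenyl. Nothing available accounts for this loss. The compounds shown leave open whether a hydroxy group in place of the methoxy of 4-methoxyphenyl would hold the number up, and whether a longer chain such as propoxy would lower it further.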